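The source may report more compounds than this note shows. Statements on the series, on what has been measured and on what is new or still open speak of the compounds shown alone.

In a functional assay on the whole organism (Hindlimb, strain albino) with Mus musculus as the target, in the maximal electroshock model, with a stated time of 0.5 h (on this read-out lower numbers stand for an effect already at smaller amounts and higher numbers for an effect only at larger amounts of compound), compound 1 `CC(=O)N1N=C(Nc2nc3ccccc3s2)CC1c1ccc(Cl)cc1` gives 209 umol/kg and compound 2 `COc1ccc(C2CC(Nc3nc4ccccc4s3)=NN2C(C)=O)cc1` gives 226 umol/kg on the same read-out. Among the compounds with values here, these two numbers lie within the scatter of each other, so compound 2 cannot be ranked against the only other measured compound. Compound 3 `CC(=O)N1N=C(Nc2nc3ccccc3s2)CC1c1ccc(O)cc1` remains to be measured. It differs from compound 2 by hydrogen in place of methyl on an oxygen on an aromatic ring with hydrogen in place of methyl on an oxygen on an aromatic ring, which reads as methoxy to hydroxy. Within the data shown here, the only measured step at this part of the structure is a 1.1-fold higher number from compound 1 to compound 2 (0.03 log units; within the scatter) where methoxy stands in place of chloro on an aromatic carbon. That step stayed within the scatter. Among the measured compounds shown here, it is a different exchange, however, and no measured compound here carries hydroxy, so the support is thin. No step beyond the scatter is therefore expected in this assay and no direction can be given. The expected step is a 1.0-fold higher number from compound 2 to compound 3 (0.01 log units; within the scatter) and it carries wide uncertainty. For compound 3 the estimate is 230 umol/kg with an expected range of 110 umol/kg to 480 umol/kg on this read-out.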

Compound 3, dose for half-maximal effect: 249 umol/kg
Beside the measured number, compound 3's estimate is 1.1-fold (0.03 log units) below it, and the stated range covers the measured number.
By their numbers in this assay, from the lowest: compounds 1, 2 and 3 (each within the scatter of the next).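

At this position on the aromatic ring, this assay now covers three groups, and hydrogen in place of methyl on the oxygen gives a 1.1-fold higher number from compound 2 to compound 3 (0.04 log units; within the scatter), so this read-out does not separate methoxy from hydroxy. Going directly from the chloro group to the hydroxy group gives a 1.2-fold higher number from compound 1 to compound 3 (0.08 log units; within the scatter), which means that, together with the earlier methoxy-for-chloro step, all three pairs among chloro, methoxy and hydroxy lie within the scatter and the three groups cannot be ranked. Nothing available accounts for this absence of separation among the three compounds.

As far as these compounds go, whether the same picture holds for other kinds of group at this place, such as an amine, a carboxylic acid or a longer alkoxy chain, remains open. All three compounds also share the rest of the structure, so they give no indication of how the number would respond to an exchange elsewhere on the shared core.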